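Swapping the chlorophenyl for thiophene on the cinnamamide chain

The compounds below may be only part of what the source reports. "The series", "measured", "known", "first", "only" and "open" are said of these compounds alone.

Compound 2 `O=C(/C=C/c1ccccc1Cl)Nc1ccc2ncnc(Nc3cccc(Cl)c3)c2c1` was tested in a functional assay on A549 cells (Homo sapiens) for antiproliferative activity, read by MTT assay, with a stated time of 48 h (a lower number here means a stronger inhibitor, a higher number a weaker inhibitor), where compound 2 gives 4.58 ug/mL. Among the compounds with values here, its only measured neighbour is compound 1 `O=C(/C=C/c1ccccc1Cl)Nc1ccc2ncnc(Nc3cccc(Br)c3)c2c1`, which in this assay gives 6.63 ug/mL. The two differ in a single halogen on the aniline ring, and the step of a 1.4-fold lower number from compound 1 to compound 2 (0.16 log units; within the scatter) is within the scatter, so compound 2 carries the smaller of the two numbers without being distinguishable from compound 1.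

Compound 3 `O=C(/C=C/c1cccs1)Nc1ccc2ncnc(Nc3cccc(Cl)c3)c2c1` changes a different part of the molecule: thiophen-2-yl in place of 2-chlorophenyl on a double-bonded chain carbon bound to a double-bonded chain carbon. Within the data shown here, no measured step touches this end of the structure; the one step known, between the halogens on the aniline ring, says nothing about the acrylamide aryl group. With no guidance from the data, the expectation for compound 3 is a number close to that of compound 2, with a wide range to allow for an effect in either direction. Compound 3 is therefore estimated at 6 ug/mL, with a range from 2 ug/mL to 18 ug/mL. This estimate means an expected step of a 1.3-fold higher number from compound 2 to compound 3 (0.12 log units; within the scatter), not beyond the scatter.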

Compound 3, half-maximal inhibitory concentration: 9.23 ug/mL
Beside the measured number, compound 3's estimate is 1.5-fold (0.19 log units) below it; low and high end bracket the measured number.
By their numbers in this assay, from the lowest: compounds 2, 1 and 3 (each within the scatter of the next).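

The exchange of 2-chlorophenyl for thiophen-2-yl on a double-bonded chain carbon bound to a double-bonded chain carbon gives, in this assay, a 2.0-fold higher number from compound 2 to compound 3 (0.30 log units; within the scatter). This is the first reading at this place, since the earlier pair spoke only to the halogen on the aniline ring, and it shows that a six-membered aromatic ring of carbon only, carrying chlorine, and a five-membered aromatic ring with a sulfur atom cannot be told apart here, so the chlorine and the six-membered ring are not shown to be needed for a number in this range. The data offer no measurement that could explain this result, and with a step inside the scatter there is little to explain.

From the compounds shown here alone, it remains open what a plain phenyl, a furan-2-yl or a dimethylamino group would give at this same place, and so whether any group there produces a step beyond the scatter. Going by these compounds, it is also open whether thiophen-2-yl gives a similar reading when the aniline ring carries bromine instead of chlorine.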